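The compounds below may be only part of what the source reports. "The series", "measured", "known", "first", "only" and "open" are said of these compounds alone.

Measured in a functional assay on NCI-H1299 cells (Homo sapiens) for inhibition, read by scintillation counting, with a stated time of 30 min, tested at 30 uM; on this read-out lower numbers stand for less inhibition and higher numbers for more inhibition at the one concentration tested (going by the name of the read-out):
Compound 1 `COc1cccc(OC(=O)c2cc(O)c(O)c(O)c2)c1OC(=O)c1cc(O)c(O)c(O)c1`: 58.4%
Compound 2 `O=C(Oc1ccc(Cl)cc1OC(=O)c1ccc(O)c(O)c1)c1ccc(O)c(O)c1`: 94.4%
Compound 3 `COc1cccc(C(=O)Oc2cccc(OC)c2OC(=O)c2cccc(OC)c2)c1`: 32.1%

Compound 3 stands lowest of the three in this assay. Compound 1 gives a number above it that lies beyond the scatter, and compound 2 gives the highest of the three, also beyond the scatter from compound 3. Compound 4 `COc1cccc(C(=O)Oc2cccc(OC(=O)c3cccc(OC)c3)c2OC(=O)c2cccc(OC)c2)c1` has not yet been measured. Against compound 3 the change is (3-methoxyphenyl)carbonyl in place of methyl on an oxygen on an aromatic ring. For the measured compounds named here, no measured pair carries the same change, so the expectation rests on compound 3 alone; the expected step is small, within the scatter, with no clear direction. The estimate for compound 4 in this assay is 34%, with a range from 16% to 52%. The step this estimate implies, a number 1.9 percentage points higher from compound 3 to compound 4 (within the scatter), is expected to fall within the scatter.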

Compound 4, a percentage reported as inhibition, at one concentration (the size of the read-out at that concentration, not a potency): 66.2%
Compound 4: the middle estimate sits 32.2 percentage points below what was measured, outside the stated range (above it).
By their numbers in this assay, from the lowest: compound 3; then compounds 1 and 4 (each within the scatter of the next); then compound 2.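

In this assay the step of a number 34.1 percentage points higher from compound 3 to compound 4 (beyond the scatter) is large and comes from (3-methoxyphenyl)carbonyl in place of methyl on an oxygen on an aromatic ring. This position therefore responds strongly to the group it carries, and a group of far more heavy atoms than methyl is accepted there without loss. Nothing at hand bears on why the number rises.

Going by these compounds, this rests on a single step, so it remains open whether the carbonyl or the aromatic ring carries the change. An acetyl or a benzyl group on the same oxygen would separate the two.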